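The source may hold more compounds than are shown below. What is called first, only, known or untested is meant among the compounds shown, and "the series" means these compounds.

In an assay for displacement of a labelled ligand from DNA repair protein REV1 (Homo sapiens), read by fluorescence polarization, with a stated time of 1 h, tested at 1 uM (a lower number here means less inhibition, a higher number more inhibition at the concentration tested (going by the name of the read-out)), compound 1 `CCc1ccc(NC(=O)CN2CCN(c3ccc(F)cc3)CC2)cc1` gives 50%; compound 2 `CCCC1CCc2c(sc(NC(=O)C3CCN(C(C)=O)CC3)c2C(N)=O)C1` gives 50%; compound 3 `CC(=O)N1CCC(C(=O)Nc2sc3c(c2C(N)=O)CCC(C)C3)CC1` gives 50%.

Compound 1 stands level with compounds 2 and 3 at the digits shown, all three within the usual scatter of this assay. Compound 4 `N#Cc1ccc(NC(=O)CN2CCN(c3ccc(F)cc3)CC2)cc1` has not yet been measured; it differs from compound 1 in one place: cyano in place of ethyl on an aromatic carbon. Among the compounds with values here, the only measured step, no change at the digits printed from compound 2 to compound 3 (within the scatter), concerns a different core and a saturated chain carbon, so it does not speak directly to a change on an aromatic carbon. With nothing that bears on this change, no shift beyond the scatter is expected in this assay, and the step of no change at the digits printed from compound 1 to compound 4 (within the scatter) is estimated to stay within it. Compound 4 is therefore expected to give about 50%, in the range 30% to 70%.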

Compound 4, a percentage reported as inhibition, at one concentration (the size of the read-out at that concentration, not a potency): 50%
Beside the measured number, compound 4's estimate shows no gap at the digits printed, within the range that was stated.
By their numbers in this assay, from the lowest: compounds 1, 2, 3 and 4 (each within the scatter of the next).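

In this assay, the earlier step concerned a saturated chain on another core, whereas this one reads the aromatic carbon directly. Cyano brings a triple bond and a hydrogen-bond acceptor that ethyl lacks, yet the result is no change at the digits printed from compound 1 to compound 4 (within the scatter), so at one concentration this position does not separate the two groups. No measurement at hand offers an explanation for this.

From the compounds shown here alone, whether an amine, a carboxylic acid or a longer chain at this position would move the reading stays open. So does whether compound 1 and compound 4 would match across other concentrations.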